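A few compounds are considered here, and "the series" means these few. Any claim that something is new, unique, unknown or untested is made for them only; others in the source may bear on it.

Compound 1 `Cc1nc(S(C)(=O)=O)ccc1Oc1ncnc(OC2CCN(C(=O)SC(C)C)CC2)c1F` gives 41.3 nM in a functional assay on isolated protein for inhibition of Glucose-dependent insulinotropic receptor (Rattus norvegicus), read by HTRF and cAMP accumulation; a lower number here means that less compound is needed, a higher number that more compound is needed for the effect.
Compound 2 `Cc1nc(S(C)(=O)=O)ccc1Oc1ncnc(OC2CCN(C(=O)C(F)(F)F)CC2)c1F` gives 880 nM in this assay.
Compound 3 `Cc1nc(S(C)(=O)=O)ccc1Oc1ncnc(OC2CCN(C(=O)c3noc(C(C)C)n3)CC2)c1F` gives 176 nM in this assay.

Of these three, compound 1 shows the lowest number, so it needs the least compound for the effect. The three compounds share one core and differ only in the group attached to a carbonyl carbon whose other neighbour is an amide-type nitrogen in a ring. Both changes made so far at that carbonyl carbon raised the number: a 21-fold higher number from compound 1 to compound 2 (1.33 log units; beyond the scatter), a large loss, and a 4.3-fold higher number from compound 1 to compound 3 (0.63 log units; beyond the scatter), a modest loss. Between the two, the aromatic ring fared better than the trifluoromethyl, as a 5.0-fold lower number from compound 2 to compound 3 (0.70 log units; beyond the scatter) shows.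

Compound 4 `Cc1nc(S(C)(=O)=O)ccc1Oc1ncnc(OC2CCN(C(=O)c3ncc(Cl)cn3)CC2)c1F` is the next step from compound 1. The change is 5-chloropyrimidin-2-yl in place of isopropylsulfanyl on a carbonyl carbon. Like compound 3, compound 4 carries an aromatic ring at that position, so the step from compound 1 to compound 3 is the closest guide, with the step to compound 2 marking a worse case. The expected step is therefore a modest rise, a 3.6-fold higher number from compound 1 to compound 4 (0.56 log units; beyond the scatter). For compound 4 the estimate in this assay is 150 nM, with a range from 55 nM to 450 nM.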

Compound 4, half-maximal effective concentration: 30.9 nM
The estimate for compound 4 lay 4.9-fold (0.69 log units) above the measured number; measured number outside the range, below it.
By their numbers in this assay, from the lowest: compounds 4 and 1 (each within the scatter of the next); then compound 3; then compound 2.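

Until now, every replacement of isopropylsulfanyl at this carbonyl carbon had raised the number, but 5-chloropyrimidin-2-yl breaks that run, with a 1.3-fold lower number from compound 1 to compound 4 (0.13 log units; within the scatter), so a group with a six-membered aromatic ring and no sulfur can stand here and match compound 1 in this assay. Carrying an aromatic ring does not by itself fix the result, as the two ring-bearing groups clearly part, with a 5.7-fold lower number from compound 3 to compound 4 (0.76 log units; beyond the scatter), while the distance from the trifluoromethyl group is far wider, with a 28-fold lower number from compound 2 to compound 4 (1.45 log units; beyond the scatter). Nothing shown here gives a measured property of these groups that would account for these differences in the number.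

Going by these compounds, whether the chlorine matters remains open, as does how an unsubstituted pyrimidin-2-yl ring, or one with a methyl or a nitrile in place of the chlorine, would compare with compound 4. It is also unknown whether a plain phenyl ring, or an isopropoxy group in place of isopropylsulfanyl, would stay level with compound 1 and compound 4 or fall back towards compound 3.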